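The compounds below may be only part of what the source reports. "The series", "measured", "known", "first", "only" and "open" are said of these compounds alone.

Compound 1 `NS(=O)(=O)c1ccc(-c2nc(C(c3ccc(F)cc3)c3ccc(F)cc3)sc2CC(=O)O)cc1` gives 1500 nM in an in vitro assay on HEK385-7 cells for displacement of a labelled ligand from prostaglandin D2 receptor 2 (Homo sapiens); on this read-out lower numbers stand for stronger inhibition and higher numbers for weaker inhibition. Compound 2 `O=C(O)Cc1sc(C(c2ccc(F)cc2)c2ccc(F)cc2)nc1-c1cn[nH]c1` gives 16 nM; compound 3 `O=C(O)Cc1sc(C(c2ccc(F)cc2)c2ccc(F)cc2)nc1-c1ccnc(Cl)c1` gives 3.1 nM, the lowest number of the three, with a 480-fold lower number from compound 1 to compound 3 (2.68 log units; beyond the scatter) and a 5.2-fold lower number from compound 2 to compound 3 (0.71 log units; beyond the scatter). Compound 4 `O=C(O)Cc1sc(C(c2ccc(F)cc2)c2ccc(F)cc2)nc1-c1cc(F)nc(F)c1` differs from compound 3 by 2,6-difluoropyridin-4-yl in place of 2-chloropyridin-4-yl on an aromatic carbon. All three measured steps change the group at this same aromatic carbon: a 94-fold lower number from compound 1 to compound 2 (1.97 log units; beyond the scatter), a 480-fold lower number from compound 1 to compound 3 (2.68 log units; beyond the scatter) and a 5.2-fold lower number from compound 2 to compound 3 (0.71 log units; beyond the scatter). None of them swaps one halogenated pyridin-4-yl for another; the pyridine ring and its single acceptor stay. A step within the scatter, or a modest one in either direction, is therefore expected, a 1.3-fold higher number from compound 3 to compound 4 (0.11 log units; within the scatter). Compound 4 is estimated at 4 nM, within 1.5 nM to 12 nM.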

Compound 4, half-maximal inhibitory concentration: 5.4 nM
Compound 4: middle estimate off by 1.4-fold (0.13 log units), on the low side; low and high end bracket the measured number.
By their numbers in this assay, from the lowest: compounds 3 and 4 (each within the scatter of the next); then compound 2; then compound 1.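

With a 1.7-fold higher number from compound 3 to compound 4 (0.24 log units; within the scatter) at this aromatic carbon, 2,6-difluoropyridin-4-yl and 2-chloropyridin-4-yl cannot be told apart, so a second halogenated pyridin-4-yl holds the level of the first. The new group also keeps the lead over the other two, with a 3.0-fold lower number from compound 2 to compound 4 (0.47 log units; beyond the scatter) and a 280-fold lower number from compound 1 to compound 4 (2.44 log units; beyond the scatter) in this series. No measurement at hand bears on the cause of these steps. Open, going by these compounds, is whether a plain pyridin-4-yl or a 2-aminopyridin-4-yl at this carbon stays at this level. A chlorophenyl there would test whether the pyridine ring nitrogen is needed at all.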